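Replacing the 2-carboxyethyl acyl group of compound 2

This account rests on a few compounds, and the source may have more. Where it says the series, first, only, none or still open, it means among the compounds named here.

Compound 1 `O=C(Nc1cc(Nc2ccc(Cl)cc2)ncn1)c1ccc(F)cc1`: > 30000 nM (a limit)
Compound 2 `O=C(O)CCC(=O)Nc1cc(Nc2ccc(Cl)cc2)ncn1`: 1900 nM

Both compounds were tested in a functional assay on A-431 cells (Homo sapiens) for antiproliferative activity, read by MTT assay, with a stated time of 72 h; on this read-out lower numbers stand for stronger inhibition and higher numbers for weaker inhibition. For the measured compounds named here, compound 2 gives the only actual number so far, 1900 nM. For compound 1 there is only a limit: the limit of > 30000 nM in this assay, at which 1 of the 2 values shown sits.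

Compound 3 `Clc1ccc(Nc2cc(Nc3cccc(Cl)n3)ncn2)cc1` differs from compound 2 in one place: 6-chloropyridin-2-yl in place of (2-carboxyethyl)carbonyl on a nitrogen on an aromatic ring. The 2-carboxyethyl group is lost, and an aromatic ring takes over that end of the molecule.

Going by the values given here, only one measured step bears on this: an at least 15-fold lower number from compound 1 to compound 2 (1.19 log units; beyond the scatter). That large step sits on a carbonyl carbon rather than on the nitrogen, so it is only an indirect guide. It still points to a higher number in this assay, and a sizeable step is expected, though probably not a full reversal. For compound 3 the estimated value is 9000 nM, with an expected range of 2500 nM to 30000 nM. The expected change is a 4.7-fold higher number from compound 2 to compound 3 (0.68 log units; beyond the scatter).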

Compound 3, half-maximal inhibitory concentration: > 30000 nM
Compound 3: only a limit was reported; the forecaster's own chance of this, stated with the estimate: 30%; middle value at least 3.3-fold (0.52 log units) from the limit.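

On the nitrogen on an aromatic ring, 6-chloropyridin-2-yl in place of (2-carboxyethyl)carbonyl gives an at least 15-fold higher number from compound 2 to compound 3 (1.19 log units; beyond the scatter) in this assay. The value of compound 3, > 30000 nM, is a limit and not a number. An aromatic ring at this end, held through a carbonyl in compound 1 or directly on the nitrogen in compound 3, goes with the limit in both cases, and compound 2 alone gives a number: the limit of > 30000 nM in this assay, at which 2 of the 3 values shown sit.

Compound 1 and compound 3 both stand at a limit, so they cannot be ordered against each other. On these data alone, whether the carboxylic acid or the carbonyl on the nitrogen goes with the measurable value of compound 2 stays open; a methyl ester, an acetyl group or a longer chain ending in a carboxylic acid would bear on this.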